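Lengthening the acid chain of compound 2

This account rests on a few compounds, and the source may have more. Where it says the series, first, only, none or still open, it means among the compounds named here.

Compound 1 `Nc1nc2[nH]c(CCCCCCC(=O)N[C@@H](CCC(=O)O)C(=O)O)cc2c(=O)[nH]1`: > 1000 nM
Compound 2 `Nc1nc2[nH]c(CCCCCC(=O)O)cc2c(=O)[nH]1`: > 1000 nM

In a functional assay on D4 cells (Cricetulus griseus) for inhibition, read by CellTiter-Blue, with a stated time of 96 h, in the presence of a further agent that is not named here (on this read-out higher numbers stand for weaker inhibition and lower numbers for stronger inhibition), compound 2 gives > 1000 nM, which is a limit and not a number. In this assay compound 1 gives > 1000 nM, also a limit. Compound 3 `Nc1nc2[nH]c(CCCCCCCCC(=O)O)cc2c(=O)[nH]1` carries 3-carboxypropyl in place of carboxy on a saturated chain carbon, five bonds along the chain from an aromatic carbon. Among the measured compounds shown here, no measured step bears on this change, and the expected step of a number no higher from compound 2 to compound 3 (the limit leaves the size open) stays within the scatter in this assay. For compound 3 the estimated value is 1000 nM, with an expected range of 300 nM to 3000 nM.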

Compound 3, half-maximal inhibitory concentration: > 1000 nM
Compound 3 was reported as a limit (the forecaster's own chance of this, stated with the estimate: 85%); the middle value sits exactly at the limit.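

Compound 2 and compound 3 are both reported only as limits, and the step between them cannot be read. The compounds shown leave open whether the length of the acid chain affects inhibition at all: the limit of > 1000 nM in this assay, at which 3 of the 3 values shown sit.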